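A Methyl on the Urea Phenyl of Compound 2

The source may hold more compounds than are shown below. What is called first, only, known or untested is meant among the compounds shown, and "the series" means these compounds.

In a functional assay on MDA-MB-231 cells (Homo sapiens) for inhibition, with a stated time of 72 h (on this read-out higher numbers stand for weaker inhibition and lower numbers for stronger inhibition), compound 2 `O=C(Nc1ccccc1)Nc1nc(Nc2ccccc2)cc(Sc2c[nH]c3ccccc23)n1` gives 35900 nM, the higher of the two numbers measured here. Compound 1 `O=C(Nc1ccccc1)Nc1nc(NC2CC2)cc(Sc2c[nH]c3ccccc23)n1` gives 7860 nM, and the change between them is a 4.6-fold higher number from compound 1 to compound 2 (0.66 log units; beyond the scatter). Compound 3 `Cc1ccc(NC(=O)Nc2nc(Nc3ccccc3)cc(Sc3c[nH]c4ccccc34)n2)cc1` differs from compound 2 by methyl in place of hydrogen on an aromatic carbon, turning phenylcarbamoyl into (4-methylphenyl)carbamoyl. Going by the values given here, no measured step touches this position; the one step seen, a 4.6-fold higher number from compound 1 to compound 2 (0.66 log units; beyond the scatter), alters a different group and offers no guide to size or direction. For compound 3 the expected step is a 1.2-fold lower number from compound 2 to compound 3 (0.08 log units; within the scatter), within the scatter, with an estimated 30000 nM and a range from 10000 nM to 90000 nM.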

Compound 3, half-maximal inhibitory concentration: 13400 nM
For compound 3 the middle estimate is 2.2-fold (0.35 log units) above the measured one, and the stated range covers the measured number.
By their numbers in this assay, from the lowest: compounds 1 and 3 (each within the scatter of the next); then compound 2.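

The urea phenyl turns out to be a position that responds to a small change: in this assay, going from phenyl to 4-methylphenyl gives a 2.7-fold lower number from compound 2 to compound 3 (0.43 log units; beyond the scatter) and so stronger inhibition. This single added carbon has a modest effect, but one beyond the scatter. Nothing at hand explains the effect of the methyl.

As far as these compounds go, how a methoxy group, a chlorine atom or a longer chain at this place would read remains open. So does whether the same methyl would act alike on compound 1, which carries cyclopropyl instead of phenyl on the nitrogen.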